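Cyano for ethoxycarbonyl on the shared core

The source may hold more compounds than are shown below. What is called first, only, known or untested is meant among the compounds shown, and "the series" means these compounds.

In a functional assay on MKN-45 cells (Homo sapiens) for inhibition, read by MTT assay (on this read-out lower numbers stand for stronger inhibition and higher numbers for weaker inhibition), compound 1 `N#CCC(=O)Nc1sc(C(=O)Nc2ccc(Cl)cc2)c(-c2ccccc2)c1C#N` gives 590 nM and compound 2 `CCOC(=O)c1c(NC(=O)CC#N)sc(C(=O)Nc2ccccc2)c1-c1ccccc1` gives 590 nM as well, so compound 2 stands level with compound 1. Compound 3 `N#CCC(=O)Nc1sc(C(=O)Nc2ccccc2)c(-c2ccccc2)c1C#N` carries cyano in place of ethoxycarbonyl on an aromatic carbon. For the measured compounds named here, no measured pair shows this exchange on its own. Compound 1 also bears cyano and gives 590 nM in this series, so no change beyond the scatter is expected in this assay for this exchange. The expected size of a 1.0-fold higher number from compound 2 to compound 3 (0.01 log units; within the scatter) is therefore small. In this assay the estimate for compound 3 is 600 nM with an expected range of 250 nM to 1400 nM for now.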

Compound 3, half-maximal inhibitory concentration: 9140 nM
Beside the measured number, compound 3's estimate is 15-fold (1.18 log units) below it, outside the stated range (above it).
By their numbers in this assay, from the lowest: compounds 1 and 2 (each within the scatter of the next); then compound 3.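

In this assay, the ring position bearing ethoxycarbonyl is not indifferent to this exchange: cyano in place of ethoxycarbonyl gives a 15-fold higher number from compound 2 to compound 3 (1.19 log units; beyond the scatter). On the cyano-bearing core, the chloro also counts, since hydrogen in place of chloro gives a 15-fold higher number from compound 1 to compound 3 (1.19 log units; beyond the scatter). No evidence at hand accounts for either step.

Open, as far as these compounds go, is whether the cyano exchange would be as large with chloro present on the phenylcarbamoyl group. Also open, from the compounds shown here alone, is whether a carboxylic acid or a primary amide at this ring position would read closer to ethoxycarbonyl or to cyano.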